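Swapping a Saturated Ring for a Methoxyphenyl Ring

This account rests on a few compounds, and the source may have more. Where it says the series, first, only, none or still open, it means among the compounds named here.

Compound 1 `O=C(O)c1ccccc1-c1ccc(CCc2ncc(CC3CCCCCC3)[nH]2)cc1` is the reference point in this set. For the measured compounds named here, in an in vitro functional assay on cells for agonist activity at Bombesin receptor subtype-3 (Homo sapiens), read by luminescence and calcium flux (a lower number here means that less compound is needed, a higher number that more compound is needed for the effect), compound 1 gives 88 nM, the lowest of the three numbers measured so far. Compound 2 `N#Cc1ccccc1Cc1cnc(CCc2ccc(-c3ccccc3C(=O)O)cc2)[nH]1` gives 5480 nM, and compound 3 `CC(C)(C)c1cnc(CCc2ccc(-c3ccccc3C(=O)O)cc2)[nH]1` gives 4330 nM. Both changes away from compound 1 weakened the effect sharply: there was a 62-fold higher number from compound 1 to compound 2 (1.79 log units; beyond the scatter) and a 49-fold higher number from compound 1 to compound 3 (1.69 log units; beyond the scatter), while the two weaker compounds sit close together, with a 1.3-fold lower number from compound 2 to compound 3 (0.10 log units; within the scatter).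

Compound 4 `COc1cccc(Cc2cnc(CCc3ccc(-c4ccccc4C(=O)O)cc3)[nH]2)c1` has not yet been measured. Its difference from compound 1 is 3-methoxyphenyl in place of cycloheptyl on a saturated chain carbon bound to an aromatic carbon; a six-membered aromatic ring of carbon only, carrying one hydrogen-bond acceptor, takes the place of a seven-membered non-aromatic ring of carbon only. Going by the values given here, the closest precedent is the step from compound 1 to compound 2, where an aromatic ring likewise replaced the cycloheptyl at the same place and the number rose by a 62-fold higher number from compound 1 to compound 2 (1.79 log units; beyond the scatter). A large rise in this assay is therefore expected for compound 4 as well. Compound 4 is estimated to give 4000 nM, with a range from 800 nM to 20000 nM. That estimate corresponds to a 45-fold higher number from compound 1 to compound 4 (1.66 log units; beyond the scatter).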

Compound 4, half-maximal effective concentration: 4120 nM
Estimate against measurement, compound 4: 1.0-fold (0.01 log units) below; the range from low to high includes it.
By their numbers in this assay, from the lowest: compound 1; then compounds 4, 3 and 2 (each within the scatter of the next).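

A second aromatic ring at this place, 3-methoxyphenyl, costs about as much as 2-cyanophenyl did in this assay (with a 47-fold higher number from compound 1 to compound 4 (1.67 log units; beyond the scatter)), so the loss does not depend on one particular aromatic ring or its substituent. The two aromatic groups cannot be told apart (with a 1.3-fold lower number from compound 2 to compound 4 (0.12 log units; within the scatter)), and neither can 3-methoxybenzyl and the much smaller tert-butyl (with a 1.1-fold lower number from compound 3 to compound 4 (0.02 log units; within the scatter)), which leaves three different groups on one level and only the cycloheptylmethyl of compound 1 clear of them. No measurement shown here explains this shared level.

On these data alone, it remains open whether a smaller saturated ring, such as cyclohexylmethyl or cyclopentylmethyl, would keep the low number of compound 1. As far as these compounds go, it is equally open whether a saturated ring carrying a methoxy group would do so.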